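The source may hold more compounds than are shown below. What is called first, only, known or untested is meant among the compounds shown, and "the series" means these compounds.

Values in a functional assay on ECV-304 cells (Homo sapiens) for cytotoxicity (a higher number here means a weaker inhibitor, a lower number a stronger inhibitor), each one a limit of the assay and not a number:

- compound 1 `O=C1/C(=C/c2ccccc2F)SC(=S)N1NS(=O)(=O)c1ccccc1` gives > 50000 nM
- compound 2 `O=C1/C(=C/c2ccc([N+](=O)[O-])cc2)SC(=S)N1NS(=O)(=O)c1ccccc1` gives > 50000 nM
- compound 3 `O=C1/C(=C/c2ccc(C(F)(F)F)cc2)SC(=S)N1NS(=O)(=O)c1ccccc1` gives > 50000 nM

Compound 2 gives > 50000 nM, which is a limit and not a number. It therefore has no exact place in the series, and the wider picture is the limit of > 50000 nM in this assay, at which 3 of the 3 values shown sit.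

The next compound is compound 4 `O=C1/C(=C/c2ccc(Br)c(Br)c2)SC(=S)N1NS(=O)(=O)c1ccccc1`. Its change from compound 2 is 3,4-dibromophenyl in place of 4-nitrophenyl on a double-bonded chain carbon bound to a double-bonded ring carbon, with 3,4-dibromophenyl in place of 4-nitrophenyl on a double-bonded chain carbon bound to a double-bonded ring carbon.

Among the measured compounds shown here, two measured steps bear on this change, as both alter the same aromatic group: a step that the two limits leave unreadable from compound 1 to compound 2 and a step that the two limits leave unreadable from compound 2 to compound 3. Neither has a readable size, so they offer only weak guidance. With only those two steps to go on, no step beyond the scatter is expected in this assay, in either direction. The expected change is a number no higher from compound 2 to compound 4 (the limit leaves the size open). Compound 4 is estimated at 50000 nM, with an expected range from 25000 nM to 100000 nM.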

Compound 4, half-maximal inhibitory concentration: > 50000 nM
Compound 4 was reported as a limit; the forecaster's own chance of this, stated with the estimate: 75%; the middle value lies on the limit itself.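

Compound 4 gives > 50000 nM in this assay and this is a limit, not a number. Among the compounds shown here, no step linking compound 4 to compound 1 or compound 2 can therefore be read. The compounds shown leave open whether any aromatic group on the shared core would give an exact number in this assay at all, given this picture: the limit of > 50000 nM in this assay, at which 4 of the 4 values shown sit.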